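This account rests on a few compounds, and the source may have more. Where it says the series, first, only, none or still open, it means among the compounds named here.

Working notes on the series. In a functional assay on the whole organism (strain Kunming) for inhibition, with Mus musculus as the target, in the writhing test, at a dose of 40 mg/kg by the oral route (on this read-out lower numbers stand for less inhibition and higher numbers for more inhibition at the one dose given (going by the name of the read-out)), compound 1 `O=C(Oc1ccc(-c2ccc(F)cc2F)cc1C(=O)O)c1ccccc1` gives 7.97%. Compound 2 `CNC(=O)c1cc(-c2ccc(F)cc2F)ccc1OC(C)=O` gives 29.9% in this assay, and compound 3 `CCNC(=O)c1cc(-c2ccc(F)cc2F)ccc1OC(C)=O` gives 23.9% in this assay. Among the compounds with values here, the one step between measured compounds that differ in a single place, a number 6 percentage points lower from compound 2 to compound 3 (within the scatter), lies within the scatter. Within the data shown here, on the numbers so far compound 3 sits together with compound 2, the two within the scatter of each other, and both stand beyond the scatter above compound 1.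

Compound 4 `CC(=O)Oc1ccc(-c2ccc(F)cc2F)cc1C(=O)NCc1ccccc1` is not yet measured in this assay. It differs from compound 3 by phenyl in place of methyl on a saturated chain carbon bound to an amide-type nitrogen. Among the measured compounds shown here, the only measured step at this place, a number 6 percentage points lower from compound 2 to compound 3 (within the scatter), stayed within the scatter, so a change on the saturated chain carbon bound to an amide-type nitrogen has so far left the read-out where it was. No step beyond the scatter is therefore expected in this assay for compound 4, though phenyl in place of methyl is a larger change than any step measured here, so the range is set wide. The expected step is a number 1.9 percentage points lower from compound 3 to compound 4 (within the scatter). Compound 4 is estimated at 22%, with a range from 8% to 38%.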

Compound 4, a percentage reported as inhibition, in the whole organism at one dose (the size of the read-out at that dose, not a potency): 16.6%
Estimate against measurement, compound 4: 5.4 percentage points above; measured number inside the range.
By their numbers in this assay, from the lowest: compounds 1, 4, 3 and 2 (each within the scatter of the next, the first and the last beyond it).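

At the saturated chain carbon bound to an amide-type nitrogen, phenyl in place of methyl gives a number 7.3 percentage points lower from compound 3 to compound 4 (within the scatter) in this assay, so this change alone stays inside the scatter. Phenyl in place of hydrogen at the same carbon gives the first step at this place that clears the scatter, a number 13.3 percentage points lower from compound 2 to compound 4 (beyond the scatter), though only modestly; the larger group therefore does cost some inhibition at this dose when set against the unextended methylamide, a drop that the methyl step alone did not show. Nothing available explains this step.

The compounds shown leave open whether a longer chain, such as phenylethyl in place of benzyl, would lower the read-out further. They also leave open whether an amine or a carboxylic acid on this chain would keep it at the level of compound 2.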